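The source may hold more compounds than are shown below. What is called first, only, known or untested is meant among the compounds shown, and "the series" means these compounds.

Going by the values given here, only two compounds have numbers so far in an ADME assay on Caco-2 cells (Homo sapiens) for permeability, read by LC-MS, in the apical to basolateral direction, with a stated time of 60 min, at pH 6.5; a higher number here means that the compound crosses the layer faster, a lower number that the compound crosses the layer more slowly. In this test, compound 1 `CC(C)(C)[C@@H](O)C(=O)N1C[C@@H]2C[C@@H]2[C@H]1C(=O)NCc1cc(Cl)ccc1-n1cnnn1` gives 17 10^-6 cm/s. Compound 2 `CCCC[C@@H](O)C(=O)N1C[C@H]2C[C@H]2[C@H]1C(=O)NCc1cc(Cl)ccc1-n1cnnn1` gives 33 10^-6 cm/s, and these two values lie within the usual scatter of each other, so neither can be said to cross the cell layer faster. Compound 3 `O=C(NCc1cc(Cl)ccc1-n1cnnn1)[C@@H]1[C@@H]2C[C@@H]2CN1C(=O)[C@H](O)c1ccccc1F` has yet to be measured. It carries 2-fluorophenyl in place of butyl on a saturated chain carbon bound to a carbonyl carbon and an oxygen on a saturated carbon. Among the compounds with values here, no two measured compounds differ in just one place, so the data offer no direct guide to the size of this change. The estimated step of a 1.7-fold lower number from compound 2 to compound 3 (0.22 log units; within the scatter) points to a somewhat lower number but is expected to stay within the scatter. For compound 3 the estimate is 20 10^-6 cm/s, with an expected range from 8 10^-6 cm/s to 45 10^-6 cm/s.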

Compound 3, apparent permeability: 2.3 10^-6 cm/s
Compound 3: the middle estimate sits 8.7-fold (0.94 log units) above what was measured; measured number outside the range, below it.
By their numbers in this assay, from the lowest: compound 3; then compounds 1 and 2 (each within the scatter of the next).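

In this assay, going by these compounds alone, this position proves sensitive to what it carries: 2-fluorophenyl in place of butyl gives a 14-fold lower number from compound 2 to compound 3 (1.16 log units; beyond the scatter) and so a large step, the first single change here whose size can be read. Neither group has hydrogen-bond donors, hydrogen-bond acceptors or a net charge, so these counts do not tell the two apart, while the swap replaces an open chain of four carbons with an aromatic ring bearing fluorine. Nothing measured here gives a reason for this step.

Still open, on these data alone, is whether the step goes with the aromatic ring, the fluorine or the added heavy atoms. A plain phenyl would test the fluorine, and a cyclohexyl group at the same carbon would test the aromatic ring.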